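The compounds below may be only part of what the source reports. "The series", "measured", "known", "first", "only" and "open" are said of these compounds alone.

Measured so far in a functional assay on ileum (Cavia porcellus) for antagonist activity at cysteinyl leukotriene receptor (Homo sapiens); on this read-out lower numbers stand for stronger inhibition and higher numbers for weaker inhibition:
Compound 1 `CCC(CC)(CC(=O)Nc1cccc(OCc2ccc3ccc(C(F)(F)F)cc3n2)c1)C(=O)O`: 3 nM
Compound 2 `CCC(CC)(CC(=O)Nc1cccc(OCc2ccc3ccc(C)cc3n2)c1)C(=O)O`: 11 nM

Among the compounds with values here, of these two, compound 2 gives the higher number in this assay; the only step measured, a 3.7-fold higher number from compound 1 to compound 2 (0.56 log units; beyond the scatter), separates them. Compound 3 `CCC(CC)(CC(=O)Nc1cccc(OCc2ccc3cc(C)c(C)cc3n2)c1)C(=O)O` differs from compound 2 by methyl in place of hydrogen on an aromatic carbon. Within the data shown here, that measured step concerns a different group at a different place, so it bears only loosely on this change, and no measured pair shows what adding a second methyl does. The step of a 1.1-fold higher number from compound 2 to compound 3 (0.04 log units; within the scatter) is therefore expected to stay within the scatter. For compound 3 the estimate is 12 nM, with a range from 4 nM to 40 nM.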

Compound 3, half-maximal inhibitory concentration: 11 nM
Estimate against measurement, compound 3: 1.1-fold (0.04 log units) above; measured number inside the range.
By their numbers in this assay, from the lowest: compound 1; then compounds 2 and 3 (each within the scatter of the next).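

Adding a methyl on the aromatic carbon ortho to the existing methyl group gives no change at the digits printed from compound 2 to compound 3 (within the scatter) in this assay and so costs no readable inhibition. Within the data shown here, this position therefore accepts one extra carbon, whereas the earlier compounds showed only that swapping the group at a different place, a 3.7-fold higher number from compound 1 to compound 2 (0.56 log units; beyond the scatter), shifts the number. No measurement here explains why the number holds. On these data alone, whether an ethyl, a methoxy or an amine would be accepted at this position stays open. So does whether this added methyl would have the same outcome alongside trifluoromethyl.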